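This account rests on a few compounds, and the source may have more. Where it says the series, first, only, none or still open, it means among the compounds named here.

Measured so far:
- compound 1, `CCCC/C(=C\C=C\C(=O)N[C@H](C)CCCc1cccnc1)c1ccc(OC)cc1`: 0.68 mg/kg
- compound 2, `CC[C@H](CCCc1cccnc1)NC(=O)/C=C/C=C(c1ccc(OC)cc1)c1ccc(OC)cc1`: 0.16 mg/kg
- compound 3, `Cc1ccc(C(=C/C=C/C(=O)N[C@H](C)CCCc2cccnc2)c2ccc(C)cc2)cc1`: 0.3 mg/kg

All three were run in a functional assay with platelet-activating factor receptor (Cavia porcellus) as the target; a lower number here means that less compound is needed, a higher number that more compound is needed for the effect. Compound 1 stands with the highest of the three numbers. Its nearest neighbour is compound 3, whose number is lower by a margin beyond the scatter; the widest gap is to compound 2, also beyond the scatter. Compounds 2 and 3 carry a second aryl group on the double-bonded chain carbon where compound 1 carries butyl, so neither pair is a single-point step, and no more is read from those two values than their order relative to compound 1.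

The next compound, compound 4, `CC/C(=C\C=C\C(=O)N[C@H](C)CCCc1cccnc1)c1ccc(OC)cc1`, differs from compound 1 only in that chain: hydrogen in place of ethyl on a saturated chain carbon, two bonds along the chain from a double-bonded chain carbon, which cut one bond further out reads butyl to ethyl. Among the compounds with values here, no measured pair in this set isolates a change in chain length, so the size of the step is not anchored by data. The expectation is a small move, if any, towards a higher number, likely within or just beyond the scatter, as a 1.5-fold higher number from compound 1 to compound 4 (0.17 log units; within the scatter) is estimated.

Compound 4 is therefore expected to give about 1 mg/kg in this assay, within a range of 0.4 mg/kg to 2.5 mg/kg.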

Compound 4, dose for 50% inhibition: 0.68 mg/kg
Beside the measured number, compound 4's estimate is 1.5-fold (0.17 log units) above it, and the stated range covers the measured number.
By their numbers in this assay, from the lowest: compounds 2 and 3 (each within the scatter of the next); then compounds 1 and 4 (each within the scatter of the next).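

In this assay the series gains its first single-point step, with no change at the digits printed from compound 1 to compound 4 (within the scatter) on going from butyl to ethyl on this chain. The earlier compounds shown here could give only an order, whereas this pair isolates the chain: the outer ethyl on a saturated chain carbon, two bonds along the chain from a double-bonded chain carbon, can be replaced by hydrogen with the number staying within the scatter. Nothing in the data shown accounts for this result.

What the compounds shown leave open is whether this tolerance extends to a longer chain such as hexyl, or to a chain ending in a polar group such as an amine or a carboxylic acid. Also open, going by these compounds, is how far the chain can be shortened below ethyl, for instance to methyl or to hydrogen on the double-bonded chain carbon itself, and how either chain would compare in a single-point step with the second aryl group carried by compound 2 and compound 3.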